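A few compounds are considered here, and "the series" means these few. Any claim that something is new, unique, unknown or untested is made for them only; others in the source may bear on it.

In a functional assay on A549 cells (Homo sapiens) for antiproliferative activity, read by MTT assay, with a stated time of 72 h (a lower number here means a stronger inhibitor, a higher number a weaker inhibitor), compound 1 (`O=C(CCCCCCc1nc(-c2ccc(C(F)(F)F)cc2)no1)NO`) gives 14000 nM and compound 2 (`Nc1ccccc1NC(=O)CCCCCCc1nc(-c2ccccc2)no1`) gives 23900 nM. Among the measured compounds shown here, these two values lie within the scatter of each other, so compound 2 cannot be separated from the only other measured compound. Compound 3 (`Nc1ccccc1NC(=O)CCCCCCc1nc(-c2ccc(C(F)(F)F)cc2)no1`) has trifluoromethyl in place of hydrogen on an aromatic carbon of compound 2, para to a large group, which turns phenyl into 4-(trifluoromethyl)phenyl (trifluoromethyl in place of hydrogen on an aromatic carbon). For the measured compounds named here, no measured pair isolates this change, so the data give no direct precedent for its size. In this assay no shift beyond the scatter is expected, with only a slight lean towards a lower number. The expected change, a 1.5-fold lower number from compound 2 to compound 3 (0.17 log units; within the scatter), is therefore small. For compound 3 the estimated value is 16000 nM, with an expected range of 6000 nM to 40000 nM.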

Compound 3, half-maximal inhibitory concentration: > 100000 nM
Compound 3 gave a limit, no number (the forecaster's own chance of this, stated with the estimate: 10%); middle value at least 6.2-fold (0.79 log units) from the limit.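

In this assay compound 3 gives > 100000 nM, a limit of the assay and not a number: the limit of > 100000 nM in this assay, at which 1 of the 3 values shown sits.

This position is not indifferent to the change, as trifluoromethyl in place of hydrogen on the aromatic carbon para to a large group gives an at least 4.1-fold higher number from compound 2 to compound 3 (0.62 log units; beyond the scatter). With 4-(trifluoromethyl)phenyl held constant, 2-aminophenyl in place of hydroxy on the amide-type nitrogen gives an at least 7.1-fold higher number from compound 1 to compound 3 (0.85 log units; beyond the scatter), so 4-(trifluoromethyl)phenyl does not by itself push a compound to the limit, given that compound 1 carries it and still gives a number.

As far as these compounds go, the full size of both steps remains open, as each has only a lower bound. Also open, from the compounds shown here alone, is whether a smaller group at the same place, such as fluorine or methoxy, or a shorter chain alongside the 2-aminophenyl amide, would give a measurable value.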